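Adding a chlorine to the phenyl ring of compound 3

This account rests on a few compounds, and the source may have more. Where it says the series, first, only, none or still open, it means among the compounds named here.

Measured so far in a functional assay on HEK293 cells for positive allosteric modulation of metabotropic glutamate receptor 5 (Homo sapiens), read by FLIPR and calcium flux; on this read-out higher numbers stand for an effect only at larger amounts of compound and lower numbers for an effect already at smaller amounts:
compound 1, `O=C1c2ccc(C#Cc3ccccc3)nc2CCN1C1CCCC1`, gives 5.9 nM;
compound 2, `O=C1c2ccc(C#Cc3cccs3)nc2CCN1C1CCCC1`, gives 12 nM;
compound 3, `O=C1c2ccc(C#Cc3ccccc3)nc2CCN1C1CCCCC1`, gives 40 nM.

Among these three, compound 3 shows the highest number in this assay, with a 6.8-fold higher number from compound 1 to compound 3 (0.83 log units; beyond the scatter) separating it from compound 1, and compound 2 sitting between them.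

Compound 4, `O=C1c2ccc(C#Cc3cccc(Cl)c3)nc2CCN1C1CCCCC1`, is compound 3 with one change: chloro in place of hydrogen on an aromatic carbon. The place is on an aromatic carbon of a six-membered aromatic ring of carbon only, meta to a large group; put another way, phenyl becomes 3-chlorophenyl.

Among the compounds with values here, none of the measured steps touches this position. The nearest comparison is the swap of the whole aryl group on the triple bond, a 2.0-fold higher number from compound 1 to compound 2 (0.31 log units; beyond the scatter), which was modest. The other step, a 6.8-fold higher number from compound 1 to compound 3 (0.83 log units; beyond the scatter), concerns the ring on the amide-type nitrogen and says nothing about the phenyl. With no direct guide, the expected step of a 1.3-fold lower number from compound 3 to compound 4 (0.12 log units; within the scatter) is small, likely within the scatter, in either direction.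

Compound 4 is therefore estimated at 30 nM in this assay, with a range from 8 nM to 120 nM.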

Compound 4, half-maximal effective concentration: 171 nM
Estimate against measurement, compound 4: 5.7-fold (0.76 log units) below, and the stated range ends below it.
By their numbers in this assay, from the lowest: compound 1; then compound 2; then compound 3; then compound 4.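

In this assay, a single chlorine on the phenyl ring gives a 4.3-fold higher number from compound 3 to compound 4 (0.63 log units; beyond the scatter), so more of compound 4 is needed for the same effect. Within the data shown here, this is the first measured sign that the phenyl ring is sensitive to substitution at this position: even one added heavy atom moves the result beyond the usual scatter, and here in the unfavourable direction. No measurement here explains why the chlorine has this effect.

The compounds shown leave open whether the change comes from chlorine in particular or from any group at this position, as a fluorine, a methyl or a methoxy group could show. They also leave open whether 3-chlorophenyl would cost as much on compound 1, which carries cyclopentyl rather than cyclohexyl on the amide-type nitrogen.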